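The source may report more compounds than this note shows. Statements on the series, on what has been measured and on what is new or still open speak of the compounds shown alone.

Working notes on the trichloro-free trimethoxy ketone pair. Compound 1 `CCCC(=O)c1c(OC)c(Cl)c(OC)c(Cl)c1OC` gives 20800 nM in a functional assay on the whole organism (S2 cells, strain S2) for inhibition, with Drosophila as the target, read by a luciferase reporter, with stated times of 1.5 h and 8 h (a higher number here means a weaker inhibitor, a lower number a stronger inhibitor), the lower of the two numbers recorded, though compound 2 `CCCC(=O)c1c(O)c(Cl)c(O)c(Cl)c1O` at 21500 nM sits within the scatter of it, so the two cannot be ordered. For the measured compounds named here, the next member, compound 3 `CCCCCCC(=O)c1c(OC)c(Cl)c(OC)c(Cl)c1OC`, carries propyl in place of hydrogen on a saturated chain carbon, three bonds along the chain from a carbonyl carbon, a change for which no measured pair gives guidance. With nothing to anchor a direction, the expected step of a 1.4-fold lower number from compound 1 to compound 3 (0.14 log units; within the scatter) is set near zero, not beyond the scatter. Compound 3 is therefore estimated at 15000 nM, in the range 4000 nM to 60000 nM.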

Compound 3, half-maximal inhibitory concentration: 16800 nM
Beside the measured number, compound 3's estimate is 1.1-fold (0.05 log units) below it; measured number inside the range.
By their numbers in this assay, from the lowest: compounds 3, 1 and 2 (each within the scatter of the next).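

Propyl in place of hydrogen on a saturated chain carbon, three bonds along the chain from a carbonyl carbon, gives a 1.2-fold lower number from compound 1 to compound 3 (0.09 log units; within the scatter) in this assay. This position therefore takes the added propyl without a shift beyond the scatter, so compound 1 and compound 3 cannot be ordered. Nothing available explains this result.

A single step defines no trend with chain length. As far as these compounds go, whether a longer chain or an amine at this position would move the number, and whether propyl behaves alike on compound 2, stay open.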